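Heteroaryl variation on the shared core: compound 4 outlook

This account rests on a few compounds, and the source may have more. Where it says the series, first, only, none or still open, it means among the compounds named here.

The series keeps one core and varies the aromatic group attached to it. Compound 1 `COc1ccc2c(OCc3nnc4sc(-c5ccc[nH]5)nn34)ccnc2c1` carries a 1H-pyrrol-2-yl group; in a functional assay on EBC-1 cells (Homo sapiens) for antiproliferative activity, with a stated time of 72 h (a higher number here means a weaker inhibitor, a lower number a stronger inhibitor), compound 1 gives 313 nM. Compound 2 `COc1ccc2c(OCc3nnc4sc(-c5cnn(C)c5)nn34)ccnc2c1` carries a 1-methyl-1H-pyrazol-4-yl group, and in this assay compound 2 gives 88 nM. Among the measured compounds shown here, the only step between single-point changes is a 3.6-fold lower number from compound 1 to compound 2 (0.55 log units; beyond the scatter). Compound 3 `COc1ccc2c(OCc3nnc4sc(-c5cc6cc(F)ccc6[nH]5)nn34)ccnc2c1` carries a 5-fluoro-1H-indol-2-yl group; in this assay compound 3 gives "not determined" (no result reported), so it stands nowhere on the numbers shown. Compound 4 `COc1ccc2c(OCc3nnc4sc(-c5ccncc5)nn34)ccnc2c1` differs from compound 3 by pyridin-4-yl in place of 5-fluoro-1H-indol-2-yl on an aromatic carbon. For the measured compounds named here, no measured step covers this exchange; the step from compound 1 to compound 2 is the nearest comparison, as it also replaces a five-membered group bearing a hydrogen-bond donor with one bearing none, and that step was modest. The expectation is therefore a number for compound 4 in this assay in the region spanned by compounds 1 and 2, with wide uncertainty. Compound 4 is estimated at 160 nM, in the range 40 nM to 700 nM.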

Compound 4, half-maximal inhibitory concentration: 289 nM
Estimate against measurement, compound 4: 1.8-fold (0.26 log units) below; the range from low to high includes it.
By their numbers in this assay, from the lowest: compound 2; then compounds 4 and 1 (each within the scatter of the next).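

In this assay, the pyridin-4-yl group now gives two readings at this aromatic carbon: a 3.3-fold higher number from compound 2 to compound 4 (0.52 log units; beyond the scatter), and a 1.1-fold lower number from compound 1 to compound 4 (0.03 log units; within the scatter). Neither pyridin-4-yl nor 1-methyl-1H-pyrazol-4-yl carries a hydrogen-bond donor, yet compound 2 and compound 4 lie apart beyond the scatter, while pyridin-4-yl and the donor-bearing 1H-pyrrol-2-yl do not, so the absence of a donor alone does not track with the lower number among these compounds. No measured evidence accounts for these differences.

The compounds shown do not separate the contribution of the methyl group from that of the pyrazole ring in compound 2. They also leave open how an amine or a carboxylic acid on the pyridine ring of compound 4 would read in this assay.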